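This account rests on a few compounds, and the source may have more. Where it says the series, first, only, none or still open, it means among the compounds named here.

Compound 3, `CCCS(=O)(=O)Nc1ccc(F)c(C(=O)c2n[nH]c3ncc(-c4ccc(C(C)(C)C)cc4)cc23)c1F`, is the weakest of the three measured compounds in an assay for binding affinity to dual specificity mitogen-activated protein kinase kinase 4 (Homo sapiens), read by KINOMEscan, tested at 100 nM; on this read-out higher numbers stand for a weaker effect at the one concentration tested and lower numbers for a stronger effect: compound 3 gives 46%. Its nearest neighbour is compound 1, `CCCS(=O)(=O)Nc1ccc(F)c(C(=O)c2n[nH]c3ncc(-c4cccc(Cl)c4)cc23)c1F`, which in this assay gives 40%; the step of a number 6 percentage points higher from compound 1 to compound 3 (within the scatter) lies within the scatter. Farthest away is compound 2, `CCCS(=O)(=O)Nc1ccc(F)c(C(=O)c2n[nH]c3ncc(-c4ccc(C)cc4)cc23)c1F`, which gives 5.4%; the step of a number 40.6 percentage points higher from compound 2 to compound 3 (beyond the scatter) is large and beyond the scatter.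

Compound 4, `CCCS(=O)(=O)Nc1ccc(F)c(C(=O)c2n[nH]c3ncc(-c4ccc(S(N)(=O)=O)cc4C)cc23)c1F`, differs from compound 3 in one place: 2-methyl-4-sulfamoylphenyl in place of 4-(tert-butyl)phenyl on an aromatic carbon. Going by the values given here, no measured step covers a sulfamoyl group, so the closest guide is the step of a number 40.6 percentage points higher from compound 2 to compound 3 (beyond the scatter), where methyl gave a far stronger effect than tert-butyl, and the step of a number 34.6 percentage points lower from compound 1 to compound 2 (beyond the scatter), showing that a para substituent on this phenyl ring can shift the read-out a great deal. Since compound 4 again carries a methyl rather than a tert-butyl, a step downward is expected, though the sulfamoyl group adds real uncertainty.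

The estimated step is a number 26 percentage points lower from compound 3 to compound 4 (beyond the scatter), so compound 4 is expected to give about 20%, between 3% and 55%.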

Compound 4, a percentage reported as activity, at one concentration (the size of the read-out at that concentration, not a potency): 3.1%
For compound 4 the middle estimate is 16.9 percentage points above the measured one; measured number inside the range.
By their numbers in this assay, from the lowest: compounds 4 and 2 (each within the scatter of the next); then compounds 1 and 3 (each within the scatter of the next).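

In this assay, the change to 2-methyl-4-sulfamoylphenyl gives a number 42.9 percentage points lower from compound 3 to compound 4 (beyond the scatter) and a number 36.9 percentage points lower from compound 1 to compound 4 (beyond the scatter), so this position also admits a group with a hydrogen-bond donor and hydrogen-bond acceptors, which the three earlier phenyl groups lack, while keeping a strong effect. The change from 4-methylphenyl gives only a number 2.3 percentage points lower from compound 2 to compound 4 (within the scatter), so a ring carrying the sulfamoyl group and the 2-methyl group together stays level with the simple 4-methylphenyl ring. Nothing given here accounts for these steps.

The compounds shown leave open how much of the result belongs to the sulfamoyl group and how much to the 2-methyl group, as the two enter in one change. Also open, from the compounds shown here alone, is how a carboxylic acid or an amine would read on this ring.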